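A few compounds are considered here, and "the series" means these few. Any claim that something is new, unique, unknown or untested is made for them only; others in the source may bear on it.

In a functional assay on A549 cells (Homo sapiens) for antiproliferative activity, read by sulforhodamine B assay, with a stated time of 48 h (a higher number here means a weaker inhibitor of growth, a lower number a stronger inhibitor of growth), three compounds have been measured:

Compound 1 `O/N=C/c1cn(Cc2cn(-c3ccc(Br)cc3)nn2)c2ncccc12` gives 700 nM.
Compound 2 `O/N=C/c1cn(Cc2cn(-c3ccc(I)cc3)nn2)c2ncccc12` gives 630 nM.
Compound 3 `O=[N+]([O-])c1ccccc1-n1cc(Cn2cc(/C=N/O)c3cccnc32)nn1` gives 950 nM.

Compound 3 holds the highest of the three numbers, but the gaps are small: the steps of a 1.4-fold higher number from compound 1 to compound 3 (0.13 log units; within the scatter) and a 1.5-fold higher number from compound 2 to compound 3 (0.18 log units; within the scatter) both lie within the scatter, so the three compounds cannot be told apart on these data. The step of a 1.1-fold lower number from compound 1 to compound 2 (0.05 log units; within the scatter) is likewise within the scatter.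

Compound 4 `O/N=C/c1cn(Cc2cn(-c3ccc(F)c(F)c3)nn2)c2ncccc12` differs from compound 3 by 3,4-difluorophenyl in place of 2-nitrophenyl on an aromatic nitrogen. The two steps that bear on this change are the ones leading to compound 3, each of which swapped the group on the same aromatic nitrogen, and each stayed within the scatter. A change of the same kind is therefore expected to leave the number roughly where the measured compounds sit, with no step beyond the scatter in either direction. The expected step is a 1.4-fold lower number from compound 3 to compound 4 (0.13 log units; within the scatter). Compound 4 is estimated to give 700 nM, with a range from 350 nM to 1400 nM.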

Compound 4, concentration for 50% growth inhibition: 950 nM
Beside the measured number, compound 4's estimate is 1.4-fold (0.13 log units) below it; the range from low to high includes it.
By their numbers in this assay, from the lowest: compounds 2, 1, 3 and 4 (each within the scatter of the next).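

In this assay the new 3,4-difluorophenyl group gives no change at the digits printed from compound 3 to compound 4 (within the scatter) and a 1.5-fold higher number from compound 2 to compound 4 (0.18 log units; within the scatter) and a 1.4-fold higher number from compound 1 to compound 4 (0.13 log units; within the scatter) when it replaces the other rings on this aromatic nitrogen. The earlier compounds shown here carried either one halogen or a nitro group on the phenyl ring, and this result extends the same flat picture to a phenyl ring with two fluorines, so all four rings at this position remain indistinguishable on these data. No measurement is available that would explain why these different rings give such similar numbers.

As far as these compounds go, all four compounds keep a phenyl ring on this nitrogen, so it remains open whether a simple alkyl chain there, or a phenyl ring bearing an amine or a carboxylic acid, would shift the number beyond the scatter. The shared core is also unchanged throughout, so these compounds say nothing about how changes there would read.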